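A single swap on the amide nitrogen of a potent lead

The source may report more compounds than this note shows. Statements on the series, on what has been measured and on what is new or still open speak of the compounds shown alone.

Measured so far:
compound 1 `Cc1ccc(OCC(=O)N(Cc2cccs2)c2ncco2)cc1` — 0.3 nM
compound 2 `CCN(Cc1cccnc1)C(=O)COc1ccc(C)cc1` — 15400 nM

In an assay on HEK293 cells for agonist activity at transient receptor potential cation channel subfamily M member 8 (Homo sapiens), read by fluorescence and calcium flux, with a stated time of 15 min (on this read-out lower numbers stand for an effect already at smaller amounts and higher numbers for an effect only at larger amounts of compound), compound 1 gives 0.3 nM, the lowest of the two numbers reported, while compound 2 gives 15400 nM, a far higher figure that lies well beyond the scatter of repeated measurements. Compound 2 differs from compound 1 at more than one place, so its value shows only that the alternative arrangement is much weaker; no single-point comparison between measured compounds is available.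

Compound 3 `CCC(C)N(Cc1cccs1)C(=O)COc1ccc(C)cc1` has not yet been measured in this assay. It differs from compound 1 in one place: sec-butyl in place of 1,3-oxazol-2-yl on an amide-type nitrogen. Compound 3 keeps the rest of the lead unchanged. For the measured compounds named here, no measured pair isolates this change, so the expectation rests on the two values alone: compound 1 is very potent and the only other compound, compound 2, is weak. The step from compound 1 to compound 3 in this assay is expected to be a marked loss, a 6700-fold higher number from compound 1 to compound 3 (3.82 log units; beyond the scatter), though with wide uncertainty. For compound 3 the estimate in this assay is 2000 nM, with a range from 100 nM to 20000 nM.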

Compound 3, half-maximal effective concentration: 2000 nM
For compound 3 middle estimate and measured number coincide at the digits printed; measured number inside the range.
By their numbers in this assay, from the lowest: compound 1; then compound 3; then compound 2.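

For the compounds shown here, compound 3 gives the first comparison that changes only one place, the group on the amide-type nitrogen, and in this assay the change is large, with a 6700-fold higher number from compound 1 to compound 3 (3.82 log units; beyond the scatter) when sec-butyl stands in place of 1,3-oxazol-2-yl. Going by these compounds alone, this position is therefore far from indifferent to what it carries, at least for this pair: with the rest of the lead held constant, the one swap moves the number well beyond the scatter. The swap removes the aromatic ring, its hetero atoms and its 2 hydrogen-bond acceptors all at once, and nothing available ties the loss to any one of these features.

The compounds shown leave open which of those differences counts, since a single pair cannot separate them. A phenyl ring at this position would keep an aromatic ring without the hetero atoms, a 1,3-thiazol-2-yl group would exchange the oxygen for sulfur, and a cyclobutyl group would bring back a ring without aromatic character, so each would address a different part of the question.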